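Compound 3 to compound 4: amine change on the chain

A few compounds are considered here, and "the series" means these few. Any claim that something is new, unique, unknown or untested is made for them only; others in the source may bear on it.

In a functional assay on MCF7 cells (Homo sapiens) for antiproliferative activity (on this read-out lower numbers stand for stronger inhibition and higher numbers for weaker inhibition), compound 3 `CC(C)=CCc1cc(C(=O)Nc2cc3ccc(OCCCNCC(C)C)c(C)c3oc2=O)ccc1O` gives 1320 nM and compound 1 `CC(C)=CCc1cc(C(=O)Nc2cc3ccc(OCC4CCCN(C)C4)c(C)c3oc2=O)ccc1O` gives 2640 nM. These two values stand within the scatter, with a 2.0-fold lower number from compound 1 to compound 3 (0.30 log units; within the scatter). Compound 2 `CCCN(CCC)CCCOc1ccc2cc(NC(=O)c3ccc(O)c(CC=C(C)C)c3)c(=O)oc2c1C` reads > 50000 nM, which is a limit of the assay.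

Compound 4 `CC(C)=CCc1cc(C(=O)Nc2cc3ccc(OCCCN(C)C(C)(C)C)c(C)c3oc2=O)ccc1O` carries methyl(tert-butyl)amino in place of isobutylamino, on a saturated chain carbon, three bonds along the chain from an oxygen on an aromatic ring (methyl(tert-butyl)amino in place of isobutylamino on a saturated chain carbon, three bonds along the chain from an oxygen on an aromatic ring). Within the data shown here, the closest precedent is compound 2, at the same place, with an at least 37-fold lower number from compound 2 to compound 3 (1.57 log units; beyond the scatter). Also large is an at least 18-fold higher number from compound 1 to compound 2 (1.27 log units; beyond the scatter). A moderately higher number is therefore expected in this assay, though a large step remains possible. The estimated step is a 3.0-fold higher number from compound 3 to compound 4 (0.48 log units; beyond the scatter). For compound 4 the estimate is 4000 nM, with an expected range from 1000 nM to 30000 nM.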

Compound 4, half-maximal inhibitory concentration: 1140 nM
The estimate for compound 4 lay 3.5-fold (0.55 log units) above the measured number, within the range that was stated.
By their numbers in this assay, from the lowest: compounds 4, 3 and 1 (each within the scatter of the next, the first and the last beyond it). At a limit, above all of these: compound 2.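

In this assay, isobutylamino gives way to methyl(tert-butyl)amino at this place without a readable change, a 1.2-fold lower number from compound 3 to compound 4 (0.06 log units; within the scatter), although the hydrogen-bond donors on the group go from 1 to 0. The dipropylamino of compound 2 gives a limit of the assay and not a number, so an at least 43-fold lower number from compound 2 to compound 4 (1.64 log units; beyond the scatter) is a bound only: the limit of > 50000 nM in this assay, at which 1 of the 4 values shown sits. Replacing 1-methylpiperidin-3-yl with 2-(methyl(tert-butyl)amino)ethyl gives a modest step, a 2.3-fold lower number from compound 1 to compound 4 (0.36 log units; beyond the scatter).

Open, from the compounds shown here alone, is whether a smaller amine such as dimethylamino keeps this level on the same chain. Also open, going by these compounds, is how methyl(tert-butyl)amino behaves on a longer chain.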